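The compounds below may be only part of what the source reports. "The series", "measured", "known", "first", "only" and "open" are said of these compounds alone.

Compound 1 `CN1[C@@H]2c3[nH]c4ccccc4c3C[C@H]1[C@H](C#N)N1[C@@H](CNC(=O)c3cccc(C(F)(F)F)c3)c3[nH]c4ccccc4c3C[C@@H]21` gives 340 nM in a functional assay on HepG2 cells (Homo sapiens) for cytotoxicity, read by MTT assay, with a stated time of 72 h; a higher number here means a weaker inhibitor, a lower number a stronger inhibitor.
Compound 2 `CN1[C@@H]2c3[nH]c4ccccc4c3C[C@H]1[C@H](C#N)N1[C@@H](CNC(=O)c3ccc(Cl)cc3)c3[nH]c4ccccc4c3C[C@@H]21` gives 350 nM in this assay.
Compound 3 `CN1[C@@H]2c3[nH]c4ccccc4c3C[C@H]1[C@H](C#N)N1[C@@H](CNC(=O)c3ccc(F)cc3)c3[nH]c4ccccc4c3C[C@@H]21` gives 210 nM in this assay.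

Compound 3 has the lowest of the three numbers, yet its gaps to the others are small: a 1.6-fold lower number from compound 1 to compound 3 (0.21 log units; within the scatter) and a 1.7-fold lower number from compound 2 to compound 3 (0.22 log units; within the scatter), both within the scatter, so no order among the three compounds can be read from these values. Compound 4 `CCc1ccc(C(=O)NC[C@H]2c3[nH]c4ccccc4c3C[C@H]3[C@H]4c5[nH]c6ccccc6c5C[C@@H]([C@H](C#N)N23)N4C)cc1` differs from compound 3 by ethyl in place of fluoro on an aromatic carbon. Every measured step changes the same aryl ring, and none moved the number beyond the scatter: a 1.0-fold higher number from compound 1 to compound 2 (0.01 log units; within the scatter), a 1.6-fold lower number from compound 1 to compound 3 (0.21 log units; within the scatter), a 1.7-fold lower number from compound 2 to compound 3 (0.22 log units; within the scatter). On that basis no step beyond the scatter is expected in this assay, the expected step being a 1.2-fold higher number from compound 3 to compound 4 (0.09 log units; within the scatter). Compound 4 is estimated at 260 nM, between 120 nM and 550 nM.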

Compound 4, half-maximal inhibitory concentration: 570 nM
Compound 4: middle estimate off by 2.2-fold (0.34 log units), on the low side; the measured number lies above the stated range.
By their numbers in this assay, from the lowest: compounds 3, 1, 2 and 4 (each within the scatter of the next, the first and the last beyond it).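

Ethyl in place of fluoro, para to a large group, brings a 2.7-fold higher number from compound 3 to compound 4 (0.43 log units; beyond the scatter) in this assay and is the first step on this aryl ring to pass the scatter. Ethyl in place of chloro gives a 1.6-fold higher number from compound 2 to compound 4 (0.21 log units; within the scatter) and 4-ethylphenyl in place of 3-(trifluoromethyl)phenyl gives a 1.7-fold higher number from compound 1 to compound 4 (0.22 log units; within the scatter) so compound 4 separates only from compound 3. Nothing available here explains this step. As far as these compounds go, whether an amine, a carboxylic acid or a longer chain at this position would move the number further stays open.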